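The source may hold more compounds than are shown below. What is called first, only, known or untested is meant among the compounds shown, and "the series" means these compounds.

Measured so far in an assay on CHO cells for displacement of a labelled ligand from adenosine receptor A1 (Homo sapiens), read by scintillation counting, with a stated time of 90 min, in the presence of a further agent that is not named here; on this read-out higher numbers stand for weaker inhibition and lower numbers for stronger inhibition:

Compound 1 `CCCn1c(=O)[nH]c2nc(-c3ccc(S(=O)(=O)N4CCN(Cc5cccc(Br)c5)CC4)cc3)[nH]c2c1=O`: 928 nM
Compound 2 `CCCn1c(=O)[nH]c2nc(-c3ccc(S(=O)(=O)N4CCN(c5ccccc5)CC4)cc3)[nH]c2c1=O`: 364 nM

Within the data shown here, compound 2 gives the lowest of the two numbers so far. Its nearest neighbour is compound 1, and the step is a 2.5-fold lower number from compound 1 to compound 2 (0.41 log units; beyond the scatter), which put the phenyl directly on the ring amine in place of the 3-bromobenzyl group.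

Compound 3 `CCCn1c(=O)[nH]c2nc(-c3ccc(S(=O)(=O)N4CCN(c5ccc(I)cc5)CC4)cc3)[nH]c2c1=O` takes compound 2 one step further. The difference is iodo in place of hydrogen on an aromatic carbon of the six-membered aromatic ring of carbon only, para to a large group; cut one bond further out, it reads phenyl to 4-iodophenyl.

Among the measured compounds shown here, no measured step bears directly on this change. For the measured compounds named here, the only step known, from compound 1 to compound 2, exchanged the whole group on the ring nitrogen rather than adding a single halogen to a phenyl that stays in place, so it offers no guide to the size or direction of what is expected here. Compound 3 is therefore expected to sit near compound 2, with a step of about a 1.2-fold lower number from compound 2 to compound 3 (0.08 log units; within the scatter), which is within the scatter. The estimate for compound 3 in this assay is 300 nM, with a likely range from 100 nM to 900 nM.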

Compound 3, inhibition constant: > 1000 nM
Compound 3: a limit, no number (the forecaster's own chance of this, stated with the estimate: 3%); at least 3.3-fold (0.52 log units) between middle value and limit.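

In this assay compound 3 stands at a limit and not at a number: the limit of > 1000 nM in this assay, at which 1 of the 3 values shown sits.

This shows that the phenyl on the ring amine does not accept every change at this place: a single iodo in place of hydrogen, para to a large group, gives an at least 2.7-fold higher number from compound 2 to compound 3 (0.43 log units; beyond the scatter) and so moves the read-out towards weaker inhibition beyond the scatter, whereas the earlier step had exchanged the whole group on the ring nitrogen. The step of an at least 1.0-fold higher number from compound 1 to compound 3 (0.03 log units; that floor lies within the scatter) gives only a floor, so no order can be set between 4-iodophenyl and 3-bromobenzyl on this nitrogen.

The real size of the loss stays open behind the limit, and with iodo as the only substituent shown on this phenyl, one atom cannot say whether the change belongs to iodine itself or to any group at this place. As far as these compounds go, whether fluoro, chloro or methoxy on the same aromatic carbon would leave the read-out near that of compound 2 remains unknown, as does the outcome for iodo on any other carbon of this ring.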